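Shortening the amine chain on the core of compound 1

This account rests on a few compounds, and the source may have more. Where it says the series, first, only, none or still open, it means among the compounds named here.

Compound 1 `CCCN(CCC)c1ccc(Nc2ncc(Cl)c(Oc3cccc(NC(=O)CC)c3)n2)cc1` was tested in an assay on isolated protein for inhibition of NUAK family SNF1-like kinase 2 (Homo sapiens), read by ADP-Glo, with a stated time of 60 min, tested at 10 uM, in the presence of a further agent that is not named here (a higher number here means more inhibition at the concentration tested (going by the name of the read-out), a lower number less inhibition), and came out as "not active" (no number reported), with no number given for it. Two related compounds share its core: compound 2 `CCC(=O)Nc1cccc(Oc2nc(Nc3ccc(N(C)C)cc3OC)ncc2Cl)c1` gives 15% in this assay, and compound 3 `CCC(=O)Nc1cccc(Oc2nc(Nc3ccc(N4CCC(C)CC4)cc3OC)ncc2Cl)c1` gives "not active" (no number reported) there. Compound 4 `CCC(=O)Nc1cccc(Oc2nc(Nc3ccc(N(CC)CC)cc3)ncc2Cl)c1` has not yet been measured. It differs from compound 1 in one place: diethylamino in place of dipropylamino on an aromatic carbon. Among the compounds with values here, no measured pair of compounds shows the effect of such a change, so the data give no direction for this step, and no step beyond the usual scatter is expected in either direction. Compound 4 is expected to show only weak inhibition, estimated at 10%, with a range from 0% to 30%.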

Compound 4, a percentage reported as inhibition, at one concentration (the size of the read-out at that concentration, not a potency): 21.2%
For compound 4 the middle estimate is 11.2 percentage points below the measured one, within the range that was stated.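

Within the data shown here, compound 1 was reported as "not active" with no number, so no step from compound 1 to compound 4 can be read. As far as these compounds go, it remains open whether diethylamino in place of dipropylamino changes inhibition at all. No measurement shown here explains the result of compound 4.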